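Removing the Ring Nitrogen Methyl from Compound 1

The source may report more compounds than this note shows. Statements on the series, on what has been measured and on what is new or still open speak of the compounds shown alone.

Three bridged amines have been measured in an in vitro functional assay on SH-SY5Y cells for agonist activity at Neuronal acetylcholine receptor; alpha3/beta4 (Homo sapiens), read by FLIPR and calcium flux; a lower number here means a smaller maximal response, a higher number a larger maximal response. Compound 1, `COc1cncc(C2=CC3CC(C2)CN(C)C3)c1`, gives 27% and stands lowest of the three. Compound 3, `COc1ccc(C2=CC3CC(C2)CN(C)C3)cn1`, gives 61%, a number beyond the scatter above compound 1. Compound 2, `Fc1ccc(C2=CC3CNCC(C2)C3)cn1`, gives 140%, far above both and the only one of the three that carries a hydrogen rather than a methyl on the ring nitrogen, though it also differs in its aromatic substituent, so its two values with compound 1 show a large gap without a single isolated change.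

Compound 4, `COc1cncc(C2=CC3CNCC(C2)C3)c1`, has not yet been measured. It differs from compound 1 only in that a methyl leaves and a hydrogen enters on an amine nitrogen in a ring of the bridged core: hydrogen in place of methyl on an amine nitrogen in a ring. Within the data shown here, no single-change step has been measured between any two of the known compounds, so the size of this effect rests on inference alone.

Given that compound 2 gives 140% with the free ring nitrogen, compound 4 is expected to show a step of a number 43 percentage points higher from compound 1 to compound 4 (beyond the scatter) upward, beyond the scatter. Compound 4 is thus estimated at 70%, within a range from 30% to 130%.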

Compound 4, largest response reached (reported as percent of maximum), in percent of the reference or control that the assay uses: 145%
For compound 4 the middle estimate is 75 percentage points below the measured one, and the stated range ends below it.
By their numbers in this assay, from the lowest: compound 1; then compound 3; then compounds 2 and 4 (each within the scatter of the next).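

In this assay, among these compounds, hydrogen in place of methyl on the amine nitrogen in a ring of the bridged core gives a step of a number 118 percentage points higher from compound 1 to compound 4 (beyond the scatter) and is the first change in this set to be read on its own. The rest of the molecule stays the same, so the large rise belongs to this one exchange, in which a single carbon leaves. This position is therefore far from silent in this assay, as the loss of one methyl group is enough to turn the low maximal response of compound 1 into a high one. No measurement available here explains why the response moves so far at this nitrogen.

The compounds shown leave open how an ethyl group or a longer chain on this ring nitrogen would behave, and so whether the response falls gradually as the substituent grows or drops as soon as any carbon is attached. They also leave open whether the same exchange would bring a step of similar size on compound 3, whose aromatic ring carries its methoxy group in a different arrangement.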